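A Single Bromo Added to Compound 3

The source may hold more compounds than are shown below. What is called first, only, known or untested is meant among the compounds shown, and "the series" means these compounds.

Of the compounds shown here, three with closely related structures have been tested so far. In a functional assay on A549 cells (Homo sapiens) for antiproliferative activity, read by MTT assay, with a stated time of 48 h (on this read-out lower numbers stand for stronger inhibition and higher numbers for weaker inhibition), compound 1 `COc1ccc(-c2nnc(-c3cn4cccc(C)c4n3)o2)cc1` gives 12800 nM while compound 2 `COc1cc(-c2nnc(-c3cn4cccc(C)c4n3)o2)cc(OC)c1OC` gives 9900 nM and compound 3 `Cc1cc(Br)c2nc(-c3nnc(-c4ccccc4)o3)cn2c1` gives 14500 nM as its reading. All three values lie within the usual scatter of one another, so compound 3 stands level with compound 1 and compound 2.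

The next compound, compound 4 `Cc1cc(Br)c2nc(-c3nnc(-c4ccc(Br)cc4)o3)cn2c1`, differs from compound 3 in one place, where phenyl becomes 4-bromophenyl. This is bromo in place of hydrogen on an aromatic carbon para to a large group. Among the compounds with values here, no two measured compounds differ in just one place, so the data hold no direct measure of a change like this one. Within the data shown here, the close values so far suggest only a modest effect. The expected move is a 1.5-fold lower number from compound 3 to compound 4 (0.16 log units; within the scatter) and it should stay within the scatter, with a slight lean toward stronger inhibition. In this assay the estimate for compound 4 is 10000 nM with an expected range of 3500 nM to 25000 nM for that number.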

Compound 4, half-maximal inhibitory concentration: 23400 nM
Beside the measured number, compound 4's estimate is 2.3-fold (0.37 log units) below it; low and high end bracket the measured number.
By their numbers in this assay, from the lowest: compounds 2, 1, 3 and 4 (each within the scatter of the next, the first and the last beyond it).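

Within the data shown here, this is the first pair of measured compounds that differ in one place, so it gives the first direct reading of this change: bromo in place of hydrogen on an aromatic carbon, para to a large group, gives a 1.6-fold higher number from compound 3 to compound 4 (0.21 log units; within the scatter) in this assay. Because that step lies within the scatter, the data do not show that adding bromo at this position alters antiproliferative activity in either direction. No separate measurement bears on this result.

The compounds shown leave open whether an amine or a carboxylic acid in place of this bromo would give a reading clearly apart from that of compound 3. They also leave open whether the same bromo change would read alike on the shared core without the ring bromo that compound 3 carries.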